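Series notes: pyridin-2-yl in place of phenyl

This account rests on a few compounds, and the source may have more. Where it says the series, first, only, none or still open, it means among the compounds named here.

Measured so far in a functional assay on U-937 cells (Homo sapiens) for antiproliferative activity, read by MTT assay, with a stated time of 24 h; on this read-out higher numbers stand for weaker inhibition and lower numbers for stronger inhibition:
compound 1 `O=C1O/C(=C\Cn2cc(-c3ccccc3)nn2)C(OCc2ccccc2)=C1OCc1ccccc1`: > 100000 nM
compound 2 `CC(C)(C)c1ccc(-c2cn(CCC3(O)NC(=O)C(OCc4ccccc4)=C3OCc3ccccc3)nn2)cc1`: 56500 nM
compound 3 `COC1=C(OC)C(O)(CCn2cc(-c3ccccc3)nn2)NC1=O`: 20300 nM

Compound 1 returns only a limit of the assay, not a number, in this assay: > 100000 nM. Its standing is therefore simply (the limit of > 100000 nM in this assay, at which 1 of the 3 values shown sits). For the measured compounds named here, compound 2 does give a number in this assay, 56500 nM, and compound 3 gives 20300 nM; both differ from compound 1 in more than one place, so no single step can be drawn from them, and they show only that the series as a whole stays weak on this read-out.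

Compound 4 `O=C1O/C(=C\Cn2cc(-c3ccccn3)nn2)C(OCc2ccccc2)=C1OCc1ccccc1` differs from compound 1 in one place only: pyridin-2-yl in place of phenyl on an aromatic carbon. Going by the values given here, no step of this kind has been measured in this assay. Given that compound 1 sits at > 100000 nM, the change is expected to move the value by no more than the scatter, in no clear direction. Compound 4 is therefore estimated at 100000 nM, within 40000 nM to 300000 nM. The expected step of a number no higher from compound 1 to compound 4 (the limit leaves the size open) is within the usual scatter, and a limit rather than a number is the more likely outcome.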

Compound 4, half-maximal inhibitory concentration: 70200 nM
Estimate against measurement, compound 4: 1.4-fold (0.15 log units) above, and the stated range covers the measured number.
By their numbers in this assay, from the lowest: compound 3; then compounds 2 and 4 (each within the scatter of the next). At a limit, above all of these: compound 1.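

For the compounds shown here, for the first time at this position, a step can be drawn in this assay: replacing phenyl with pyridin-2-yl on the aromatic carbon gives an at least 1.4-fold lower number from compound 1 to compound 4 (0.15 log units; that floor lies within the scatter). Compound 1 is recorded only as a limit of the assay, > 100000 nM. The change therefore gives a measurable number without showing a gain beyond the scatter, and the true size of the step stays open because one end of it is a limit: the limit of > 100000 nM in this assay, at which 1 of the 4 values shown sits.

As far as these compounds go, whether pyridin-3-yl, pyridin-4-yl, or a phenyl bearing an amine or a carboxylic acid would give a clearly lower number at this position remains open. From the compounds shown here alone, it is also open whether pyridin-2-yl in place of phenyl would produce a similar step on the cores of compound 2 and compound 3.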